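Halogen Swap on the Benzyl Arm of Compound 3

The source may hold more compounds than are shown below. What is called first, only, known or untested is meant among the compounds shown, and "the series" means these compounds.

Compound 3 `O=c1ccoc2cc(OCc3cn(Cc4ccc(Cl)cc4)nn3)ccc12` is the only one of the three measured compounds to give a number in a functional assay on HeLa cells (Homo sapiens) for cytotoxicity, read by MTT assay, with a stated time of 48 h (on this read-out higher numbers stand for weaker inhibition and lower numbers for stronger inhibition), where compound 3 reaches 37600 nM. Compound 1 `O=c1ccoc2cc(OCc3cn(Cc4ccccc4)nn3)ccc12` gives only the limit > 100000 nM in this assay. Compound 2 `Cc1ccc(Cn2cc(COc3ccc4c(=O)ccoc4c3)nn2)cc1` likewise gives only the limit > 100000 nM. Both limits sit at the limit of > 100000 nM in this assay, at which 2 of the 3 values shown sit. The steps of an at least 2.6-fold lower number from compound 1 to compound 3 (0.42 log units; beyond the scatter) and an at least 2.6-fold lower number from compound 2 to compound 3 (0.42 log units; beyond the scatter) are at least modest, while a step that the two limits leave unreadable from compound 1 to compound 2 cannot be read. Compound 4 `O=c1ccoc2cc(OCc3cn(Cc4cccc(Br)c4)nn3)ccc12` differs from compound 3 by 3-bromophenyl in place of 4-chlorophenyl on a saturated chain carbon bound to an aromatic nitrogen. Going by the values given here, no measured step swaps chloro for bromo or moves a halogen within the benzyl ring. Compound 4 is therefore expected near compound 3, with a step of a 1.3-fold lower number from compound 3 to compound 4 (0.10 log units; within the scatter) expected to stay within the scatter. Compound 4 is estimated at 30000 nM, between 10000 nM and 100000 nM.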

Compound 4, half-maximal inhibitory concentration: > 100000 nM
Compound 4 gave a limit, no number; the forecaster's own chance of this, stated with the estimate: 35%; middle value at least 3.3-fold (0.52 log units) from the limit.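

In this assay, replacing 4-chlorophenyl with 3-bromophenyl on the saturated chain carbon bound to an aromatic nitrogen gives an at least 2.6-fold higher number from compound 3 to compound 4 (0.42 log units; beyond the scatter), so this place is sensitive to the change. A halogen on the benzyl ring therefore does not by itself secure a number: compound 3 gives one, while compound 4, also halogenated, does not. The steps linking compound 4 to compound 1 and compound 2 cannot be read, as all three stand at a limit: the limit of > 100000 nM in this assay, at which 3 of the 4 values shown sit.

As far as these compounds go, it remains open whether the halogen itself or its place on the ring drives the step. From the compounds shown here alone, how an amine or a carboxylic acid on the benzyl ring would read also remains open.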